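This account rests on a few compounds, and the source may have more. Where it says the series, first, only, none or still open, it means among the compounds named here.

Measured compounds:
compound 1 `COc1ccc2c(c1)c(-c1cc(C(F)(F)F)c(C#N)c(-c3cn(S(=O)(=O)c4ccc(C)cc4)c4ccc(OC)cc34)n1)cn2S(=O)(=O)c1ccc(C)cc1`: 25%
compound 2 `COc1ccc2c(-c3cc(C(F)(F)F)c(C#N)c(-c4cn(S(=O)(=O)c5ccc(C)cc5)c5cc(OC)ccc45)n3)cn(S(=O)(=O)c3ccc(C)cc3)c2c1`: 33%
compound 3 `COc1ccc2c(c1)c(-c1cc(C(F)(F)F)ccn1)cn2S(=O)(=O)c1ccc(C)cc1`: 16.9%

All three numbers come from a functional assay on A549 cells (Homo sapiens) for inhibition, tested at 0.1 uM; on this read-out higher numbers stand for a stronger effect at the one concentration tested and lower numbers for a weaker effect. In this assay compound 3 gives 16.9%, the smallest of the three numbers shown. The gap to compound 1 is within the scatter, so compound 3 and compound 1 cannot be told apart on these numbers; the gap to compound 2 is beyond the scatter, so compound 2 stands clearly higher than compound 3. Within the data shown here, no step between two measured compounds that differ in one place is available, so nothing yet shows what a single change does to the read-out.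

Compound 4 `Cc1ccc(S(=O)(=O)n2cc(-c3cc(C(F)(F)F)ccn3)c3ccccc32)cc1` is the next compound in this assay. It differs from compound 3 in one place: hydrogen in place of methoxy on an aromatic carbon

The rest of compound 3 is kept unchanged. Among the measured compounds shown here, compound 3 already sits near the bottom of the three numbers, and there is no measured pair to show what removing the methoxy does here. The step from compound 3 to compound 4 is therefore expected to be small, with no change beyond the scatter in either direction; the estimated step is a number 2.9 percentage points lower from compound 3 to compound 4 (within the scatter). Compound 4 is estimated at 14%, within a range from 4% to 26%.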

Compound 4, a percentage reported as inhibition, at one concentration (the size of the read-out at that concentration, not a potency): 25%
Beside the measured number, compound 4's estimate is 11 percentage points below it; the range from low to high includes it.
By their numbers in this assay, from the lowest: compounds 3, 1, 4 and 2 (each within the scatter of the next, the first and the last beyond it).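

In this assay, among these compounds, hydrogen in place of methoxy on an aromatic carbon gives a number 8.1 percentage points higher from compound 3 to compound 4 (within the scatter), the first step that isolates a single change. Compound 3 and compound 4 cannot be told apart, so on these numbers the methoxy at this position is not needed to keep the read-out at the one concentration tested, and its removal neither clearly gains nor clearly loses effect. Nothing available bears on why the two compounds read alike.

As far as these compounds go, this is one step at one position, and it tests only the absence of the methoxy, so it remains open whether a different group on this aromatic carbon, such as a chlorine, an ethoxy or an amine, would move the read-out beyond the scatter. From the compounds shown here alone, it is also open whether hydrogen in place of methoxy would behave the same way in compound 1 or compound 2, where the methoxy stands on a shared core carrying the nitrile and a second substituted unit.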